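Pyridin-4-yl Replacing 4-Chlorophenyl on a Second Core

This account rests on a few compounds, and the source may have more. Where it says the series, first, only, none or still open, it means among the compounds named here.

Compound 1 `Cc1csc(NC(=O)Cn2cc(-c3ccc(Cl)cc3)nn2)n1` gives 520 nM in a functional assay on BMDM cells (Mus musculus, strain C57BL/6) for inhibition, with a stated time of 2 days; a higher number here means a weaker inhibitor, a lower number a stronger inhibitor. Compound 2 `Cc1csc(NC(=O)Cn2cc(-c3ccncc3)nn2)n1` carries the change pyridin-4-yl in place of 4-chlorophenyl on an aromatic carbon and in this assay gives 100 nM, a step of a 5.2-fold lower number from compound 1 to compound 2 (0.72 log units; beyond the scatter). Compound 3 `CCOC(=O)c1sc(NC(=O)Cn2cc(-c3ccc(Cl)cc3)nn2)nc1C` differs from compound 1 by ethoxycarbonyl in place of hydrogen on an aromatic carbon; in this assay compound 3 gives 180 nM, which is a 2.9-fold lower number from compound 1 to compound 3 (0.46 log units; beyond the scatter). Compounds 2 and 3 lie within the scatter of each other. Compound 4 `CCOC(=O)c1sc(NC(=O)Cn2cc(-c3ccncc3)nn2)nc1C` has not yet been measured and differs from compound 3 by pyridin-4-yl in place of 4-chlorophenyl on an aromatic carbon, the same change as that from compound 1 to compound 2, on the same place. Compound 4 is therefore expected to give about 40 nM in this assay, with a range from 15 nM to 110 nM. The expected step is a 4.5-fold lower number from compound 3 to compound 4 (0.65 log units; beyond the scatter). Among the compounds with values here, this rests only on the single earlier step of a 5.2-fold lower number from compound 1 to compound 2 (0.72 log units; beyond the scatter), so the real step could be smaller.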

Compound 4, half-maximal inhibitory concentration: 120 nM
Compound 4: the middle estimate sits 3.0-fold (0.48 log units) below what was measured, and the stated range ends below it.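

In this assay the change to pyridin-4-yl did not keep its earlier size on the core bearing ethoxycarbonyl, where it gives a 1.5-fold lower number from compound 3 to compound 4 (0.18 log units; within the scatter), so the step did not carry across the two cores: the same change on two cores in this assay, a 5.2-fold lower number (0.72 log units; beyond the scatter) from compound 1 to compound 2 and a 1.5-fold lower number (0.18 log units; within the scatter) from compound 3 to compound 4, 3.5-fold (0.54 log units) apart, beyond the scatter of two such steps. Seen from the other side, adding ethoxycarbonyl to the pyridin-4-yl core gives a 1.2-fold higher number from compound 2 to compound 4 (0.08 log units; within the scatter), and this step too depends on the core: the same change on two cores in this assay, a 2.9-fold lower number (0.46 log units; beyond the scatter) from compound 1 to compound 3 and a 1.2-fold higher number (0.08 log units; within the scatter) from compound 2 to compound 4, 3.5-fold (0.54 log units) apart, beyond the scatter of two such steps. These four compounds show that the two changes do not simply add here, but they cover one pair of changes only and do not show why the steps differ.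

From the compounds shown here alone, it remains open whether a carboxylic acid or a primary amide in place of ethoxycarbonyl would behave in the same way. The same holds for an unsubstituted phenyl in place of 4-chlorophenyl.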